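The source may hold more compounds than are shown below. What is called first, only, known or untested is meant among the compounds shown, and "the series" means these compounds.

Of the compounds shown here, three that share one core have been measured in a physicochemical assay for solubility, in phosphate buffer, measured as kinetic solubility; a lower number here means a less soluble compound, a higher number a more soluble compound: compound 1 `CC(C)C(Cc1ncc[nH]1)c1ccc(-c2ccc3cccc(F)c3c2)[nH]c1=O` gives 22100 nM, compound 2 `CC(C)C(Cc1nnn[nH]1)c1ccc(-c2ccc3cccc(F)c3c2)[nH]c1=O` gives 27300 nM and compound 3 `CC(C)C(c1noc(=O)[nH]1)c1ccc(-c2ccc3cccc(F)c3c2)[nH]c1=O` gives 32500 nM. Compound 3 therefore stands within the scatter of both others, as shown by a 1.2-fold higher number from compound 2 to compound 3 (0.08 log units; within the scatter) and by a 1.5-fold higher number from compound 1 to compound 3 (0.17 log units; within the scatter). The third measured step, a 1.2-fold higher number from compound 1 to compound 2 (0.09 log units; within the scatter), is also within the scatter.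

Compound 4 `CC(C)C(c1ccc(-c2ccc3cccc(F)c3c2)[nH]c1=O)N1CCNC1=O` differs from compound 3 by one change: a group of 6 heavy atoms (3 carbon, 2 nitrogen, 1 oxygen; one five-membered non-aromatic ring with 2 hetero atoms) in place of a group of 6 heavy atoms (2 carbon, 2 nitrogen, 2 oxygen; one five-membered aromatic ring with 3 hetero atoms), on a saturated chain carbon bound to an aromatic carbon and a saturated chain carbon. The entering group is 2-oxoimidazolidin-1-yl. All three measured steps bear on this change, since each swaps one five-membered ring for another, and none of them moves the number beyond the scatter. They bear on it only in part, however, as each of those rings is aromatic and the ring in compound 4 is not. Among the compounds with values here, the data therefore contain no direct precedent for this exchange, and they give no firm direction.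

A small step toward a lower number is expected, not clearly beyond the scatter, and the estimated step is a 1.8-fold lower number from compound 3 to compound 4 (0.26 log units; within the scatter). The range is kept wide to allow for the untested ring type. For compound 4 the estimate is 18000 nM, with an expected range from 6000 nM to 40000 nM.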

Compound 4, solubility: 24900 nM
Beside the measured number, compound 4's estimate is 1.4-fold (0.14 log units) below it; the measured number falls inside the stated range.
By their numbers in this assay, from the lowest: compounds 1, 4, 2 and 3 (each within the scatter of the next).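

In this assay, the measured exchange of an aromatic ring for a non-aromatic one at this place, on a saturated chain carbon bound to an aromatic carbon and a saturated chain carbon, gives a 1.3-fold lower number from compound 3 to compound 4 (0.12 log units; within the scatter) even though the group goes from 3 hydrogen-bond acceptors to 1 hydrogen-bond acceptor. Setting 2-oxoimidazolidin-1-yl in place of (1H-tetrazol-5-yl)methyl gives a 1.1-fold lower number from compound 2 to compound 4 (0.04 log units; within the scatter) and setting it in place of (1H-imidazol-2-yl)methyl gives a 1.1-fold higher number from compound 1 to compound 4 (0.05 log units; within the scatter) so that all four groups now lie within the scatter of one another, and the earlier lack of movement among aromatic rings extends to this non-aromatic ring. Nothing at hand offers a measured reason for this flat picture.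

Every group shown contains a five-membered ring, which leaves open whether a carboxylic acid, an amine or a six-membered ring such as morpholine at this place would stay within the same scatter. As far as these compounds go, it is also open whether an open-chain urea would behave as 2-oxoimidazolidin-1-yl does, or whether the ring itself matters to the number.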